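Swapping the five-membered ring on a shared scaffold

The source may report more compounds than this note shows. Statements on the series, on what has been measured and on what is new or still open speak of the compounds shown alone.

Compound 3 `CC(C)C(/C=C1\CCNC1=O)c1ccc(-c2ccc3cccc(F)c3c2)[nH]c1=O` stands second highest of the three numbers in a physicochemical assay for solubility, measured as kinetic solubility, at pH 2 (a lower number here means a less soluble compound, a higher number a more soluble compound), where compound 3 gives 23600 nM. Compound 1 `CC(C)C(c1ccc(-c2ccc3cccc(F)c3c2)[nH]c1=O)N1CCCCC1=O` gives 23500 nM and compound 2 `CC(C)C(Nc1nccs1)c1ccc(-c2ccc3cccc(F)c3c2)[nH]c1=O` gives 32900 nM; the steps of a 1.0-fold higher number from compound 1 to compound 3 (0.00 log units; within the scatter) and a 1.4-fold lower number from compound 2 to compound 3 (0.14 log units; within the scatter) both sit within the scatter, so no order among the three can be read. Compound 4 `CC(C)C(Cc1noc(=O)[nH]1)c1ccc(-c2ccc3cccc(F)c3c2)[nH]c1=O` differs from compound 3 by a group of 7 heavy atoms (3 carbon, 2 nitrogen, 2 oxygen; one five-membered aromatic ring with 3 hetero atoms) in place of a group of 7 heavy atoms (5 carbon, 1 nitrogen, 1 oxygen; one five-membered non-aromatic ring with 1 hetero atom), on a saturated chain carbon bound to an aromatic carbon and a saturated chain carbon. The exchanges already seen at the same place, a 1.4-fold higher number from compound 1 to compound 2 (0.15 log units; within the scatter) and a 1.0-fold higher number from compound 1 to compound 3 (0.00 log units; within the scatter), moved the number little. Compound 4 is expected to show a step of a 1.1-fold higher number from compound 3 to compound 4 (0.03 log units; within the scatter), not beyond the scatter. Compound 4 is estimated at 25000 nM, with a range from 11000 nM to 55000 nM.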

Compound 4, solubility: 18200 nM
Estimate against measurement, compound 4: 1.4-fold (0.14 log units) above; the range from low to high includes it.
By their numbers in this assay, from the lowest: compounds 4, 1, 3 and 2 (each within the scatter of the next).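

In this assay, the five-membered aromatic ring with 3 hetero atoms gives steps of a 1.3-fold lower number from compound 3 to compound 4 (0.11 log units; within the scatter) and a 1.3-fold lower number from compound 1 to compound 4 (0.11 log units; within the scatter) and a 1.8-fold lower number from compound 2 to compound 4 (0.26 log units; within the scatter) at this place. Even this group, with its 3 hydrogen-bond acceptors, leaves all four compounds within the scatter of their neighbours, so aromatic and non-aromatic rings of either size cannot be ordered here. Nothing available bears on why the number stays so level. On these data alone, whether an amine or a carboxylic acid at this place would move the number beyond the scatter stays open. So does whether a longer chain would.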